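The source may report more compounds than this note shows. Statements on the series, on what has been measured and on what is new or still open speak of the compounds shown alone.

Measured in a functional assay on MCF7 cells (Homo sapiens) for antiproliferative activity, read by CellTiter-Glo, with a stated time of 5 days; on this read-out lower numbers stand for stronger inhibition and higher numbers for weaker inhibition:
- Compound 1 `CC/C(=C(/c1ccc(/C=C/C(=O)O)cc1)c1ccc2c(cnn2C)c1)c1ccccc1`: 300 nM
- Compound 2 `CC/C(=C(/c1ccc(/C=C/C(=O)O)cc1)c1ccc2cncn2c1)c1ccccc1`: > 500 nM

For compound 2 the reading of > 500 nM is a limit of the assay and not a number, so its true position on the scale is open. Compound 3 `CC/C(=C(/c1ccc(/C=C/C(=O)O)cc1)c1ccn2ccnc2c1)c1ccccc1` has the same atoms as compound 2, joined differently: a group of 9 heavy atoms (7 carbon, 2 nitrogen; one five-membered aromatic ring with 2 hetero atoms, one six-membered aromatic ring with 1 hetero atom) in place of a group of 9 heavy atoms (7 carbon, 2 nitrogen; one five-membered aromatic ring with 2 hetero atoms, one six-membered aromatic ring with 1 hetero atom), on a double-bonded chain carbon bound to an aromatic carbon and a double-bonded chain carbon. The change sits on a double-bonded chain carbon bound to an aromatic carbon and a double-bonded chain carbon, and the rest of the molecule stays the same.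

For the measured compounds named here, only one measured step bears on this place, an at least 1.6-fold higher number from compound 1 to compound 2 (0.22 log units; that floor lies within the scatter). That step swaps a different group at the same place, and its floor does not clear the scatter. Going by the values given here, no measured step compares the two groups of compound 2 and compound 3 directly. No step beyond the scatter is therefore expected in this assay, and no direction is favoured, although the reading may again be only a limit. The step expected is an at least 1.1-fold lower number from compound 2 to compound 3 (0.04 log units; that floor lies within the scatter). The estimated value for compound 3 is 450 nM, with an expected range from 150 nM to 1000 nM.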

Compound 3, half-maximal inhibitory concentration: > 500 nM
Compound 3 was reported as a limit (the forecaster's own chance of this, stated with the estimate: 50%); middle value at least 1.1-fold (0.04 log units) away from the limit.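

In this assay compound 3 gives > 500 nM, which is a limit of the assay and not a number. Joining the same atoms differently at this double-bonded chain carbon therefore gives a second group that yields no numerical reading, and the step between compound 2 and compound 3 cannot be read, because both values are limits: the limit of > 500 nM in this assay, at which 2 of the 3 values shown sit. For the compounds shown here, the one step that can be read is an at least 1.6-fold higher number from compound 1 to compound 3 (0.22 log units; that floor lies within the scatter), so this comparison, like the earlier one with the same floor, does not establish a real loss against the group of compound 1.

From the compounds shown here alone, how far the true values of compound 2 and compound 3 lie past the limit remains open, and so does whether the two arrangements of the same atoms differ in this assay at all. Also open, going by these compounds, is how a bicyclic group of this kind would read at this place if it carried an amine or a nitrile, which could show whether the position admits any reading stronger than that of compound 1.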